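A few compounds are considered here, and "the series" means these few. Any claim that something is new, unique, unknown or untested is made for them only; others in the source may bear on it.

In an assay on cells for inhibition of Amine oxidase [flavin-containing] B (Homo sapiens), read by fluorescence, with stated times of 30 min and 15 min, tested at 1 uM (a higher number here means more inhibition at the concentration tested (going by the name of the read-out), a lower number less inhibition), compound 1 `Cn1c(=O)[nH]c2ccc(OCc3cccc(Cl)c3)cc21` gives 8.89%. Compound 2 `CC(C)=C1C(=O)Nc2ccc(OCCOc3ccccc3)cc21` is reported in this assay as "not active" (no number reported), with no number attached, and compound 3 `COc1ccc(OCCOc2ccc3c(c2)C(=C(C)C)C(=O)N3)cc1` is reported in this assay as "not active" (no number reported) in the same way. Compound 2 thus stands without a single number, one other compound stands in the same position, and the only number among these three compounds is small. Compound 4 `CC(C)=C1C(=O)Nc2ccc(OCCc3ccccc3)cc21` has not yet been measured in this assay. It differs from compound 2 in one place: phenyl in place of phenoxy on a saturated chain carbon, two bonds along the chain from an oxygen on an aromatic ring. Within the data shown here, no measured pair shows what such a change does here, so no step beyond the usual scatter is expected in either direction in this assay. Compound 4 is expected to give about 5% in this assay, within a range from 0% to 15%.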

Compound 4, a percentage reported as inhibition, at one concentration (the size of the read-out at that concentration, not a potency): "not active" (no number reported)
The entry for compound 4 holds no number, and the estimate cannot be compared.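

Compound 2 and compound 4 are both reported as not active in this assay, with no numbers, so no step can be read between them. No measured evidence bears on this result. Going by these compounds, whether phenyl in place of phenoxy changes inhibition at all remains open.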